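This account rests on a few compounds, and the source may have more. Where it says the series, first, only, none or still open, it means among the compounds named here.

Working notes on the series. Among the measured compounds shown here, compound 1 `CC1(C)[C@H]2CC[C@]1(C)N(Cc1cn(-c3cccc(F)c3)nn1)C(=O)C2` stands at 80 nM in a functional assay on HepG2 cells (Homo sapiens) for inhibition, read by MTT assay, with a stated time of 24 h (on this read-out lower numbers stand for stronger inhibition and higher numbers for weaker inhibition), the only companion number being that of compound 2 `CC1(C)[C@H]2CC[C@]1(C)N(Cc1cn(-c3ccccc3F)nn1)C(=O)C2`, which gives 60 nM in this assay. For the measured compounds named here, the single measured step, a 1.3-fold lower number from compound 1 to compound 2 (0.12 log units; within the scatter), exchanges one fluorophenyl for another and stays within the scatter. Compound 3 `CC1(C)[C@H]2CC[C@]1(C)N(Cc1cn(-c3ccc(Cl)cc3)nn1)C(=O)C2` carries the change (4-chlorophenyl in place of 3-fluorophenyl on an aromatic nitrogen). Going by the values given here, the one step on record concerns only a different fluorophenyl, not a change of halogen, so it bears on this move only loosely; it shows that the aryl group on an aromatic nitrogen can be varied without a shift beyond the scatter. Among the compounds with values here, no measured pair puts chlorine in place of fluorine, and nothing in the data points to a sizeable move either way. Compound 3 is therefore expected to show no change at the digits printed from compound 1 to compound 3 (within the scatter), not beyond the scatter. For compound 3 the estimate is 80 nM, with a range from 30 nM to 250 nM.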

Compound 3, half-maximal inhibitory concentration: 90 nM
Estimate against measurement, compound 3: 1.1-fold (0.05 log units) below; the measured number falls inside the stated range.
By their numbers in this assay, from the lowest: compounds 2, 1 and 3 (each within the scatter of the next).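

In this assay the step from 3-fluorophenyl to 4-chlorophenyl on an aromatic nitrogen, a 1.1-fold higher number from compound 1 to compound 3 (0.05 log units; within the scatter), shows that exchanging the halogen as well as moving it leaves the number within the scatter, whereas the earlier step covered only a different fluorophenyl. The step from the 2-fluorophenyl group gives the same reading, a 1.5-fold higher number from compound 2 to compound 3 (0.18 log units; within the scatter), so 2-fluorophenyl, 3-fluorophenyl and 4-chlorophenyl cannot be told apart at this position in this assay. Nothing at hand bears on why these three groups read alike.

As far as these compounds go, all three groups are halogen-bearing phenyl rings, so it remains open whether unsubstituted phenyl, a methoxyphenyl, an aminophenyl or a benzyl group would also stay within the scatter. Equally open, from the compounds shown here alone, is whether any change to the shared core would hold the number as these aryl changes do.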